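The source may report more compounds than this note shows. Statements on the series, on what has been measured and on what is new or still open speak of the compounds shown alone.

Measured compounds in a functional assay on IGROV-1 cells (Homo sapiens) for cytotoxicity, read by sulforhodamine B assay, with a stated time of 48 h, tested at 1 uM; on this read-out lower numbers stand for a stronger effect and higher numbers for a weaker effect at the one concentration tested:

- compound 1 `COc1cc(-c2cc(/C=C/C(=O)c3ccc(N)cc3)[nH]n2)cc(OC)c1OC` gives 100%
- compound 2 `COc1ccc(-c2cc(/C=C/C(=O)c3ccc(OC)c(OC)c3)[nH]n2)cc1` gives 77%
- compound 3 `COc1ccc(-c2cc(/C=C/C(=O)c3ccc(N)cc3)[nH]n2)cc1OC` gives 100%

Compound 1 stands level with compound 3 at the digits shown, the two of them together the highest numbers of the three, which on this read-out means the weakest effect at the single concentration tested. Compound 2 sits lower by an amount beyond the scatter. Among the compounds with values here, the only single-point step among the measured compounds, no change at the digits printed from compound 1 to compound 3 (within the scatter), concerns hydrogen in place of methoxy on an aromatic carbon and shows no change.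

Compound 4 `COc1cc(-c2cc(/C=C/C(=O)c3ccc(F)c(F)c3)[nH]n2)cc(OC)c1OC` differs from compound 1 in one place: 3,4-difluorophenyl in place of 4-aminophenyl on a carbonyl carbon. Within the data shown here, no measured step touches this part of the shared core, so none bears on it directly. Compound 2, which carries a different aryl group on the carbonyl carbon, shows a lower number than compound 1, but its two values speak for themselves and that pair differs in more than one place. The expectation is therefore a number near that of compound 1, with the step of a number 7 percentage points lower from compound 1 to compound 4 (within the scatter) expected to fall within the scatter, though a move toward a lower number cannot be ruled out. Compound 4 is estimated at 93%, with a range from 72% to 105%.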

Compound 4, a percentage reported as activity, at one concentration (the size of the read-out at that concentration, not a potency): 95%
For compound 4 the middle estimate is 2 percentage points below the measured one; low and high end bracket the measured number.
By their numbers in this assay, from the lowest: compound 2; then compounds 4, 1 and 3 (each within the scatter of the next).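

In this assay, within the data shown here, 3,4-difluorophenyl in place of 4-aminophenyl on the carbonyl carbon gives a number 5 percentage points lower from compound 1 to compound 4 (within the scatter), the first step to touch this place in the molecule. The exchange removes the hydrogen-bond donor and acceptor counted on 4-aminophenyl and brings in two fluorine atoms, yet at this single concentration the read-out does not separate the two groups. Nothing available explains this outcome.

With only these two groups compared at this place, a single step cannot show whether the carbonyl carbon accepts any aryl group equally in this assay. As far as these compounds go, whether a carboxylic acid or a dimethylamino group on that phenyl ring, or a longer chain in its place, would move the number beyond the scatter remains open.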